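The source may report more compounds than this note shows. Statements on the series, on what has been measured and on what is new or still open speak of the compounds shown alone.

Measured compounds:
compound 1 `CSc1ccc(-c2noc(CN3N=N[C@@H]4C(=O)N(c5ccccc5)C(=O)[C@@H]43)n2)cc1` — in an ADME assay on L6 cells (Rattus norvegicus) for cytotoxicity, read by resazurin assay, with a stated time of 72 h (a higher number here means a weaker inhibitor, a lower number a stronger inhibitor), compound 1 gives > 100 ug/mL
compound 2 `COc1ccc(-c2noc(CN3N=N[C@@H]4C(=O)N(c5ccccc5)C(=O)[C@@H]43)n2)cc1` — in this assay compound 2 gives > 100 ug/mL

The value for compound 1 is a limit of the assay, not a number. The value for compound 2 is likewise a limit. Within the data shown here, compound 1 therefore stands only at a limit, and the one further value shown is a limit as well. Among the measured compounds shown here, the single measured step, a step that the two limits leave unreadable from compound 1 to compound 2, cannot be sized because both values sit at the limit of > 100 ug/mL in this assay, at which 2 of the 2 values shown sit.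

Compound 3 `CN(C)c1ccc(-c2noc(CN3N=N[C@@H]4C(=O)N(c5ccccc5)C(=O)[C@@H]43)n2)cc1` differs from compound 1 by dimethylamino in place of methylsulfanyl on an aromatic carbon. For the measured compounds named here, the only step that bears on it is the unreadable one just described, so no size of step beyond the scatter can be read from the data. Compound 3 is accordingly expected to stay at the limit, with an estimated value of 100 ug/mL in a range from 60 ug/mL to 160 ug/mL. The expected step from compound 1 is a number no higher from compound 1 to compound 3 (the limit leaves the size open).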

Compound 3, half-maximal inhibitory concentration: > 100 ug/mL
Compound 3: a limit, no number; the forecaster's own chance of this, stated with the estimate: 80%; the middle value lies on the limit itself.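

In this assay compound 3 gives > 100 ug/mL, a limit and not a number. Among these compounds, no step among compound 1, compound 2 and compound 3 can therefore be read: the limit of > 100 ug/mL in this assay, at which 3 of the 3 values shown sit. The compounds shown leave open whether methylsulfanyl, methoxy and dimethylamino differ at all in this assay.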